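Trimming the amino side chain of compound 3

The compounds below may be only part of what the source reports. "The series", "measured", "known", "first", "only" and "open" are said of these compounds alone.

Compound 3 `NCCCC[C@H](NC(=O)CN(c1nc(Cl)nc2[nH]cnc12)C1CC1)C(=O)O` gives 31.2% in a functional assay on the whole organism (Tail, strain ICR) with Mus musculus as the target, in the tail flick test, with a stated time of 30 min, at a dose of 25 umol/kg by the oral route (a lower number here means a weaker effect, a higher number a stronger effect of the compound at the dose given), the highest of the three numbers measured. Compound 2 `CSCC[C@H](NC(=O)CN(c1nc(Cl)nc2[nH]cnc12)C1CC1)C(=O)O` gives 20.4%, and the step between the two, a number 10.8 percentage points higher from compound 2 to compound 3 (beyond the scatter), lies beyond the scatter. Compound 1 `O=C(CN(c1nc(Cl)nc2[nH]cnc12)C1CC1)NCC(=O)OCc1ccccc1` gives 18.7%, the lowest of the three. Compound 4 `O=C(O)CNC(=O)CN(c1nc(Cl)nc2[nH]cnc12)C1CC1` has not been measured. It differs from compound 3 in one place: hydrogen in place of 4-aminobutyl on a saturated chain carbon bound to an amide-type nitrogen and a carbonyl carbon. Among the measured compounds shown here, the only measured step touching this carbon is the modest gain seen when 2-aminoethyl took the place of methylsulfanyl; removing the whole 4-aminobutyl has no direct precedent, though compound 1 and compound 2, both without that amine, sit close together. Compound 4 is therefore expected to fall back modestly, a number 11.2 percentage points lower from compound 3 to compound 4 (beyond the scatter). The estimate for compound 4 is 20%, within 9% to 32%.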

Compound 4, a percentage reported as activity, at one dose (the size of the read-out at that dose, not a potency): 32.2%
For compound 4 the middle estimate is 12.2 percentage points below the measured one; measured number above the stated range.
By their numbers in this assay, from the lowest: compounds 1 and 2 (each within the scatter of the next); then compounds 3 and 4 (each within the scatter of the next).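

In this assay, the 4-aminobutyl turns out not to be needed on this carbon for this level of effect, since its replacement by hydrogen gives a number 1 percentage points higher from compound 3 to compound 4 (within the scatter). Hydrogen on the same carbon in place of 2-(methylsulfanyl)ethyl gives a number 11.8 percentage points higher from compound 2 to compound 4 (beyond the scatter), and hydrogen in place of benzyl on an oxygen next to a carbonyl group gives a number 13.5 percentage points higher from compound 1 to compound 4 (beyond the scatter), so the smallest compound shown is not a weak one. No measurement shown here explains these numbers. On these data alone, whether a single methyl on this carbon, or a primary amide in place of the carboxylic acid, would hold this level remains open.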